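The compounds below may be only part of what the source reports. "The series", "measured", "known", "first", "only" and "open" are said of these compounds alone.

Measured so far:
Compound 1, `O=S(=O)(Nc1ccc(CNc2nc(NC3CC3)nc3ccccc23)cc1)c1ccc(F)cc1`, gives 4900 nM in a functional assay on HCT-116 cells (Homo sapiens) for inhibition, read by luminescence and resazurin assay, with a stated time of 3 days; a higher number here means a weaker inhibitor, a lower number a stronger inhibitor.
Compound 2, `CCCNc1nc(NCc2ccc(NC(=O)c3ccc(F)cc3)cc2)c2ccccc2n1`, gives 1700 nM in this assay.

Of these two numbers, compound 1 holds the higher one, meaning the weaker inhibition; compound 2 sits at a lower number, and that gap is larger than the usual scatter. The two compounds differ in more than one place, so their values say only that much and cannot be tied to any single group.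

Compound 3, `CNc1nc(NCc2ccc(NS(=O)(=O)c3ccc(F)cc3)cc2)c2ccccc2n1`, keeps everything in compound 1 except one group: methyl in place of cyclopropyl on a nitrogen on an aromatic ring. Going by the values given here, no measured pair isolates this exchange, so the expectation rests on compound 1 alone. With only a small group swapped for a smaller one, the expected step is small, with no clear direction, and the number is expected to land close to that of compound 1, perhaps drifting somewhat higher. In this assay compound 3 is therefore estimated at about 6000 nM, most likely between 2000 nM and 18000 nM. This corresponds to an expected step of a 1.2-fold higher number from compound 1 to compound 3 (0.09 log units; within the scatter).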

Compound 3, half-maximal inhibitory concentration: 5300 nM
Beside the measured number, compound 3's estimate is 1.1-fold (0.05 log units) above it; the range from low to high includes it.
By their numbers in this assay, from the lowest: compound 2; then compounds 1 and 3 (each within the scatter of the next).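

In this assay, going by these compounds alone, the change from cyclopropylamino to methylamino gives a 1.1-fold higher number from compound 1 to compound 3 (0.03 log units; within the scatter), which makes this the first pair in the set that differs in only one place. On this nitrogen on an aromatic ring, a three-membered carbon ring of 3 heavy atoms can therefore give way to a methyl of 1 heavy atom with no difference that can be told from the usual scatter of the assay. No supporting measurement bears on this result, so the data offer no explanation for it.

Only these two small groups have been compared directly at this position, and compound 2, which carries a propyl chain there, also differs from compound 1 and compound 3 elsewhere, so it gives no clean reading of how chain length matters. From the compounds shown here alone, it remains open whether a larger change on this nitrogen, such as a longer chain ending in an amine or a carboxylic acid, would shift the number beyond the scatter or leave it unchanged.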